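This account rests on a few compounds, and the source may have more. Where it says the series, first, only, none or still open, it means among the compounds named here.

Compound 3 `Nc1cc(N)c2nc(-c3ccccc3)c(Sc3ccc(F)cc3)nc2c1` is one of three compounds tested in a functional assay on Hs-578T cells (Homo sapiens) for inhibition, read by sulforhodamine B assay, with a stated time of 48 h; a higher number here means a weaker inhibitor of growth, a lower number a stronger inhibitor of growth. In this assay compound 3 gives 26900 nM, the highest number among the three. Compound 2 `CCOC(=O)[C@H](CCC(=O)O)NC(=O)c1ccc(Sc2nc3cc(N)cc(N)c3nc2-c2ccccc2)cc1` gives 13800 nM, which lies within the scatter of compound 3. Within the data shown here, compound 1 `Nc1cc(N)c2nc(-c3ccccc3)c(Oc3ccc(Cl)c(Cl)c3)nc2c1` gives 10700 nM, the lowest number, and the step of a 2.5-fold higher number from compound 1 to compound 3 (0.40 log units; beyond the scatter) is the only one-place change among the measured compounds.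

Compound 4 `Nc1cc(N)c2nc(-c3ccccc3)c(Oc3ccc(F)cc3)nc2c1` has not been measured. It differs from compound 3 in one place: 4-fluorophenoxy in place of (4-fluorophenyl)sulfanyl on an aromatic carbon. Among the measured compounds shown here, the only measured step, from compound 1 to compound 3, alters both the halogen pattern and the linking group at once, so it does not isolate this change. It shows only that the 3,4-dichlorophenoxy compound gave the lower number. No clean comparison of a 4-fluorophenoxy against a (4-fluorophenyl)sulfanyl group exists here. On this basis the step of a 1.5-fold lower number from compound 3 to compound 4 (0.17 log units; within the scatter) is expected to be small, most likely a somewhat lower number, but not clearly beyond the scatter. Compound 4 is therefore estimated at 18000 nM, with a range of 7000 nM to 45000 nM.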

Compound 4, concentration for 50% growth inhibition: 20000 nM
Beside the measured number, compound 4's estimate is 1.1-fold (0.05 log units) below it; the measured number falls inside the stated range.
By their numbers in this assay, from the lowest: compounds 1, 2, 4 and 3 (each within the scatter of the next, the first and the last beyond it).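

In this assay, the first clean test of the linking atom at this position, with the 4-fluorophenyl ring held constant, gives a 1.3-fold lower number from compound 3 to compound 4 (0.13 log units; within the scatter), so exchanging (4-fluorophenyl)sulfanyl for 4-fluorophenoxy does not separate the two compounds. The halogen pattern, now isolated on the oxygen-linked series, gives a 1.9-fold higher number from compound 1 to compound 4 (0.27 log units; within the scatter), so the earlier step, a 2.5-fold higher number from compound 1 to compound 3 (0.40 log units; beyond the scatter), divides into two single changes that each stay within the scatter, and neither alone accounts for it. Nothing available explains any of these steps.

The compounds shown leave open what a 3,4-dichlorophenyl group on sulfur would give, which would complete the set of linker and halogen pairs. They also leave open how this position would respond to a group without an aromatic ring, such as an amine or a longer alkyl chain.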